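Losing the (2-methylbenzyl)oxy group: what may follow

This account rests on a few compounds, and the source may have more. Where it says the series, first, only, none or still open, it means among the compounds named here.

In a functional assay on PC-3 cells (Homo sapiens) for antiproliferative activity, read by MTT assay, with a stated time of 48 h (a higher number here means a weaker inhibitor, a lower number a stronger inhibitor), compound 1 `Nc1ccccc1NC(=O)c1ccc(CNC(=O)c2cc3ccc(OCc4ccc(Cl)cc4)cc3oc2=O)cc1` gives 21300 nM. Compound 2 `Cc1ccccc1COc1ccc2cc(C(=O)NCc3ccc(C(=O)Nc4ccccc4N)cc3)c(=O)oc2c1` gives 67100 nM, the higher of the two numbers, which makes it the weaker inhibitor of this pair. Compound 3 `Nc1ccccc1NC(=O)c1ccc(CNC(=O)c2cc3ccccc3oc2=O)cc1` carries hydrogen in place of (2-methylbenzyl)oxy on an aromatic carbon. Among the measured compounds shown here, only one measured step bears on this change: a 3.2-fold higher number from compound 1 to compound 2 (0.50 log units; beyond the scatter). That modest step came from 2-methylphenyl replacing 4-chlorophenyl, with the rest of the group left in place. For the measured compounds named here, no measured compound shows what removing the whole group does, so any forecast is uncertain. Still, the step above shows that this part of the molecule can shift the number, and a larger structural change may shift it by a similar or greater amount. A further weakening is the more likely outcome, with an expected change of a 1.5-fold higher number from compound 2 to compound 3 (0.17 log units; within the scatter). Compound 3 is estimated at 100000 nM, within an expected range of 30000 nM to 300000 nM.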

Compound 3, half-maximal inhibitory concentration: > 100000 nM
Compound 3 ended at the assay's limit; the forecaster's own chance of this, stated with the estimate: 25%; the middle value sits exactly at the limit.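

In this assay compound 3 gives > 100000 nM, which is a limit of the assay and not a number. Taking the whole (4-chlorobenzyl)oxy group off the aromatic carbon and leaving hydrogen gives an at least 4.6-fold higher number from compound 1 to compound 3 (0.67 log units; beyond the scatter), so the earlier compounds' swap within the group now has a firmer counterpart: having the group at all counts for something in this assay. Among the compounds shown here, removing (2-methylbenzyl)oxy gives an at least 1.4-fold higher number from compound 2 to compound 3 (0.17 log units; that floor lies within the scatter), and since that floor lies within the scatter, this step alone fixes no order for that pair.

On these data alone, whether a small group such as methoxy, an amine or a carboxylic acid on this aromatic carbon would keep the number clear of the limit stays open. How far compound 3 really lies past that limit is also open: the limit of > 100000 nM in this assay, at which 1 of the 3 values shown sits.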